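This account rests on a few compounds, and the source may have more. Where it says the series, first, only, none or still open, it means among the compounds named here.

The series shares one core and varies the aryl groups on it. Compound 1 `COc1cccc(-c2nc(SCC(=O)c3sc(-c4ccccc4)nc3C)[nH]c(=O)c2C#N)c1`, compound 2 `Cc1nc(-c2ccccc2)sc1C(=O)CSc1nc(-c2ccc(Cl)cc2)c(C#N)c(=O)[nH]1` and compound 3 `Cc1nc(-c2ccc(Cl)cc2)sc1C(=O)CSc1nc(-c2ccc(Cl)cc2)c(C#N)c(=O)[nH]1` have been measured in a functional assay on U-87MG ATCC cells for antiproliferative activity against U-87 MG (Homo sapiens), read by MTT assay, with a stated time of 48 h; a lower number here means a stronger inhibitor, a higher number a weaker inhibitor. In this assay compound 1 gives 59700 nM. In this assay compound 2 gives 43400 nM. In this assay compound 3 gives 53000 nM. The three numbers sit close together: the step of a 1.4-fold higher number from compound 2 to compound 1 (0.14 log units; within the scatter) and the step of a 1.2-fold higher number from compound 2 to compound 3 (0.09 log units; within the scatter) both lie within the usual scatter, so no ranking of compounds 1, 2 and 3 can be read from these data. Within the data shown here, no step is counted between compound 1 and compound 3; their two values simply show the same region.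

Compound 4 `COc1cccc(-c2nc(SCC(=O)c3sc(-c4ccc(Cl)cc4)nc3C)[nH]c(=O)c2C#N)c1` has not yet been measured. It differs from compound 3 by 3-methoxyphenyl in place of 4-chlorophenyl on an aromatic carbon. The same change has been made once already, from compound 2 to compound 1: 3-methoxyphenyl in place of 4-chlorophenyl on an aromatic carbon, where the step was a 1.4-fold higher number from compound 2 to compound 1 (0.14 log units; within the scatter). The two place descriptions agree word for word, so this is the same change, applied on a different core: the core of compound 3 differs from the core of compound 2 by chloro in place of hydrogen on an aromatic carbon. On that basis the expected step from compound 3 to compound 4 is a 1.3-fold higher number from compound 3 to compound 4 (0.12 log units; within the scatter), set beside the earlier step because the step of a 1.4-fold higher number from compound 2 to compound 1 (0.14 log units; within the scatter) stayed within the scatter. Compound 4 is accordingly estimated at 70000 nM in this assay, with an expected range from 35000 nM to 140000 nM. Given where compounds 1, 2 and 3 fall, a limit rather than a number cannot be excluded.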

Compound 4, half-maximal inhibitory concentration: 41000 nM
Compound 4: middle estimate off by 1.7-fold (0.23 log units), on the high side; the range from low to high includes it.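

In this assay, the step with 3-methoxyphenyl in place of 4-chlorophenyl, a 1.3-fold lower number from compound 3 to compound 4 (0.11 log units; within the scatter), and the step with chloro in place of hydrogen, a 1.5-fold lower number from compound 1 to compound 4 (0.16 log units; within the scatter), both lie within the usual scatter, so neither change shows a measurable effect on these cores, and the signs of these small steps carry no weight. Steps this small show only that nothing separates the two cores here; they do not show that a change with a real effect would carry over from one core to the other. The 3-methoxyphenyl change gives no detectable difference between the cores: the same change on two cores in this assay, a 1.4-fold higher number (0.14 log units; within the scatter) from compound 2 to compound 1 and a 1.3-fold lower number (0.11 log units; within the scatter) from compound 3 to compound 4, 1.8-fold (0.25 log units) apart, within the scatter of two such steps. The chloro change gives the same reading: the same change on two cores in this assay, a 1.2-fold higher number (0.09 log units; within the scatter) from compound 2 to compound 3 and a 1.5-fold lower number (0.16 log units; within the scatter) from compound 1 to compound 4, 1.8-fold (0.25 log units) apart, within the scatter of two such steps.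

On these data alone, all four compounds lie in one region of the assay, so it remains open whether any change on the aryl groups of the shared core can move the number beyond the scatter. Also open, as far as these compounds go, is what an amine or a carboxylic acid in place of the chloro or methoxy group, or a longer chain in place of the methyl group, would do on these cores.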